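This account rests on a few compounds, and the source may have more. Where it says the series, first, only, none or still open, it means among the compounds named here.

Compound 1 `Cc1cccc(C(=O)NCN2CCC(c3ccccn3)CC2)c1`: 67%
Compound 2 `Cc1cc(F)ccc1NC(=O)CN1CCC(c2cccc[n+]2[O-])CC1`: 84%

Both measured compounds were tested in a functional assay on HEK293 cells for agonist activity at D(4) dopamine receptor (Homo sapiens), read by FLIPR; a lower number here means a smaller maximal response, a higher number a larger maximal response. Compound 2 stands highest of the two numbers: in this assay compound 2 gives 84%, while compound 1 gives 67%, a number beyond the scatter below it. For the measured compounds named here, the two compounds differ in more than one place, so no single step between them is known, and their two values show only that compound 2 reaches the larger maximal response.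

Compound 3 `O=C(CN1CCC(c2cccc[n+]2[O-])CC1)Nc1cccc(Cl)c1Cl` has not been measured yet. Compared with compound 2, it differs in one place: 2,3-dichlorophenyl in place of 4-fluoro-2-methylphenyl on an amide-type nitrogen. Going by the values given here, nothing among the measured compounds shows what such an exchange of one six-membered aromatic ring of carbon only for another does in this assay, so the expectation can only be a cautious one. The step from compound 2 to compound 3 is expected to be small, a number 4 percentage points lower from compound 2 to compound 3 (within the scatter), and perhaps none beyond the scatter. On that basis compound 3 is estimated to give 80% in this assay, with a range from 60% to 100%.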

Compound 3, largest response reached (reported as efficacy), in percent of the reference or control that the assay uses: 66%
Compound 3: middle estimate off by 14 percentage points, on the high side; the range from low to high includes it.
By their numbers in this assay, from the lowest: compounds 3 and 1 (each within the scatter of the next); then compound 2.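

In this assay, the aromatic group on the amide-type nitrogen turns out to matter: placing 2,3-dichlorophenyl where 4-fluoro-2-methylphenyl stood gives a number 18 percentage points lower from compound 2 to compound 3 (beyond the scatter), while the rest of the molecule stays the same. The size of the group in simple counts does not account for this step, as both groups have the same number of heavy atoms, a single six-membered aromatic ring of carbon only, and no hydrogen-bond donors or acceptors. Nothing available explains why the maximal response changes with this exchange.

On these data alone, this single exchange removes a fluorine and a methyl and adds two chlorines all at once, so it remains open which of these changes carries the step, and a plain phenyl or a 2-methylphenyl on the same nitrogen would help to separate them. As far as these compounds go, it also remains open whether the step is specific to this pair or would extend to other groups at this position, such as a methoxyphenyl, and whether it would be the same size on a different core.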